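Swapping the aryl amine on compound 2

The compounds below may be only part of what the source reports. "The series", "measured", "known", "first", "only" and "open" are said of these compounds alone.

Compound 1 `COc1ccc(F)cc1Nc1cc(NC(=O)Nc2c(Cl)cccc2Cl)ncn1`, in a functional assay on NCI-H1581 cells (Homo sapiens) for inhibition, read by MTT assay, with a stated time of 48 h, tested at 10 uM; a lower number here means less inhibition, a higher number more inhibition at the concentration tested (going by the name of the read-out): 73.1%
Compound 2 `COc1cc(NC(=O)Nc2cc(Nc3ccc(C)c(F)c3)ncn2)cc(OC)c1`, in this assay: 38%

Of the two measured compounds, compound 2 stands lower in this assay, and compound 1 lies above it by a gap beyond the usual scatter. Compound 3 `COc1cc(NC(=O)Nc2cc(Nc3ccc(OC)c(C)c3)ncn2)cc(OC)c1` keeps the rest of compound 2 and differs only in this way: 4-methoxy-3-methylphenyl in place of 3-fluoro-4-methylphenyl on a nitrogen on an aromatic ring. Among the compounds with values here, no measured pair isolates such a swap, so its effect is unknown. Compound 3 is expected to move by a number 2 percentage points higher from compound 2 to compound 3 (within the scatter), a step not clearly beyond the scatter in either direction. For compound 3 the estimated result is 40%, within a range of 20% to 62%.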

Compound 3, a percentage reported as inhibition, at one concentration (the size of the read-out at that concentration, not a potency): 19.7%
The estimate for compound 3 lay 20.3 percentage points above the measured number, and the stated range ends above it.
By their numbers in this assay, from the lowest: compound 3; then compound 2; then compound 1.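

In this assay, within the data shown here, the group on a nitrogen on an aromatic ring proved able to move the read-out: 4-methoxy-3-methylphenyl in place of 3-fluoro-4-methylphenyl gave a number 18.3 percentage points lower from compound 2 to compound 3 (beyond the scatter) and this is the first comparison here that differs in one place. The position therefore responds to substitution, and this swap goes towards less inhibition. Nothing at hand explains the drop.

The compounds shown leave open whether losing the fluorine or gaining the methoxy drives the step, since both change together. On these data alone, how an amine or a carboxylic acid on that ring would read also remains open.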